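Replacing 2-chloro-4-fluorophenyl with 4-methoxyphenyl in compound 2

A few compounds are considered here, and "the series" means these few. Any claim that something is new, unique, unknown or untested is made for them only; others in the source may bear on it.

- compound 1 `O=C(/C=C/c1ccc([N+](=O)[O-])cc1)Nc1cc2c(Nc3ccc(F)c(Cl)c3)ncnc2cc1O[C@H]1CCOC1` gives 12000 nM
- compound 2 `COc1cc2ncnc(Nc3ccc(F)c(Cl)c3)c2cc1NC(=O)/C=C/c1ccc(F)cc1Cl` gives "not active" (no number reported)
- compound 3 `COc1cc(/C=C/C(=O)Nc2cc3c(Nc4ccc(F)c(Cl)c4)ncnc3cc2O[C@H]2CCOC2)cc(OC)c1OC` gives 4150 nM

These three results come from a functional assay on A549 cells (Homo sapiens) for cytotoxicity, read by MTT assay, with a stated time of 72 h (a higher number here means a weaker inhibitor, a lower number a stronger inhibitor), and the open question concerns compound 4 `COc1ccc(/C=C/C(=O)Nc2cc3c(Nc4ccc(F)c(Cl)c4)ncnc3cc2OC)cc1`, which has not yet been measured. In this assay compound 2 is recorded as "not active" (no number reported) and so has no number to start from, unlike compound 1 and compound 3. The move to compound 4 changes one group: 4-methoxyphenyl in place of 2-chloro-4-fluorophenyl on a double-bonded chain carbon bound to a double-bonded chain carbon. Put simply, 4-methoxyphenyl takes the place of 2-chloro-4-fluorophenyl, on a double-bonded chain carbon bound to a double-bonded chain carbon.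

One measured step changes a group at that same place: a 2.9-fold lower number from compound 1 to compound 3 (0.46 log units; beyond the scatter). There, 3,4,5-trimethoxyphenyl replaced 4-nitrophenyl. That step is modest and was taken on the core of compound 1, not the core of compound 2, so it is only a loose guide. No size can be worked out for the step from compound 2, as one end has no number. The expected direction is toward a measurable, micromolar-range result in this assay, although compound 4 could also prove inactive. For compound 4 the estimated value is 8000 nM with an expected range from 2500 nM to 30000 nM in this assay.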

Compound 4, half-maximal inhibitory concentration: "not active" (no number reported)
The entry for compound 4 holds no number, so the estimate cannot be set against anything.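

Going by these compounds alone, compound 2 and compound 4 are both recorded as "not active" in this assay, with no number for either, so no step between them can be read. The compounds shown leave open whether 4-methoxyphenyl and 2-chloro-4-fluorophenyl differ at all in their effect in this assay. No evidence is available to explain either result.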